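Swapping 3-fluorophenyl for pyridin-3-yl in compound 4

The source may hold more compounds than are shown below. What is called first, only, known or untested is meant among the compounds shown, and "the series" means these compounds.

In an ADME assay on HepG2 2.2.15 cells (Homo sapiens) for cytotoxicity (a lower number here means that less compound is tolerated, a higher number that more compound is tolerated), compound 1 `CC(C)C(=O)OCCc1c(-c2ccccc2Cl)c2cc(Cl)ccc2[nH]c1=O` gives 62000 nM, and compound 2 `O=C(COc1ccccc1)OCCc1c(-c2ccccc2Cl)c2cc(Cl)ccc2[nH]c1=O` gives 81000 nM. The step between them is a 1.3-fold higher number from compound 1 to compound 2 (0.12 log units; within the scatter).

Compound 3 `O=C(/C=C/c1cccc(F)c1)OCCc1c(-c2ccccc2Cl)c2cc(Cl)ccc2[nH]c1=O` reads > 1600000 nM, which is a limit of the assay and not a number. The steps leading to it are an at least 25-fold higher number from compound 1 to compound 3 (1.41 log units; beyond the scatter) and an at least 19-fold higher number from compound 2 to compound 3 (1.29 log units; beyond the scatter).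

Compound 4 `O=C(/C=C/c1cccnc1)OCCc1c(-c2ccccc2Cl)c2cc(Cl)ccc2[nH]c1=O` differs from it at one place: pyridin-3-yl in place of 3-fluorophenyl on a double-bonded chain carbon bound to a double-bonded chain carbon. Pyridin-3-yl stands in place of 3-fluorophenyl on a double-bonded chain carbon bound to a double-bonded chain carbon.

Among the measured compounds shown here, no measured step exchanges 3-fluorophenyl itself, so the evidence is indirect. Compound 4 keeps the ethenyl chain of compound 3, which points to a value well clear of compound 1, given an at least 25-fold higher number from compound 1 to compound 3 (1.41 log units; beyond the scatter). Yet those large steps brought in the whole 2-(3-fluorophenyl)ethenyl group, so a partial return towards a lower number is expected.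

The expected step is an at least 4.0-fold lower number from compound 3 to compound 4 (0.60 log units; beyond the scatter). For compound 4 the estimated value in this assay is 400000 nM, with an expected range from 80000 nM to 1600000 nM.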

Compound 4, half-maximal cytotoxic concentration: 39000 nM
Estimate against measurement, compound 4: 10-fold (1.01 log units) above; measured number outside the range, below it.
By their numbers in this assay, from the lowest: compounds 4, 1 and 2 (each within the scatter of the next, the first and the last beyond it). At a limit, above all of these: compound 3.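

The single exchange of 3-fluorophenyl for pyridin-3-yl gives an at least 41-fold lower number from compound 3 to compound 4 (1.61 log units; beyond the scatter) in this assay, and that size is only a lower bound, because compound 3 stands at a limit and not at a number: the limit of > 1600000 nM in this assay, at which 1 of the 4 values shown sits.

The ethenyl chain alone therefore does not carry the high reading, for 2-(pyridin-3-yl)ethenyl gives a 1.6-fold lower number from compound 1 to compound 4 (0.20 log units; within the scatter) and a 2.1-fold lower number from compound 2 to compound 4 (0.32 log units; beyond the scatter). Among these compounds, what sets compound 3 apart goes with the 3-fluorophenyl group on the chain, and compound 4 shows that another six-membered aromatic ring there does not keep it.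

As far as these compounds go, whether the fluorine or the ring nitrogen decides this stays open, and a plain phenyl on the same chain would help separate the two. From the compounds shown here alone, how far compound 3 truly lies beyond its limit also stays unknown.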